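Phenyl for Benzyl on the Urea of a Weak Inhibitor

This account rests on a few compounds, and the source may have more. Where it says the series, first, only, none or still open, it means among the compounds named here.

The account follows compound 1, `O=C(/C(=N/O)Nc1ccc(F)c(Br)c1)C1CCN(C(=O)NCc2ccccc2)CC1`, in an assay for inhibition of Tryptophan 2,3-dioxygenase (Homo sapiens), with a stated time of 1 h (a higher number here means a weaker inhibitor, a lower number a stronger inhibitor), where compound 1 gives 89800 nM. Within the data shown here, this is the only outright number in the set; the two other results are limits of the assay. Compound 2, `O=C(Nc1ccccc1)[C@H]1CC[C@H](C(=O)/C(=N/O)Nc2ccc(F)c(Br)c2)CC1`, reaches only the limit of > 100000 nM in this assay. Compound 3, `O/N=C(/CC1CCCCC1)Nc1ccc(F)c(Br)c1`, likewise stops at the limit of > 100000 nM in this assay. Among the measured compounds shown here, compound 1 therefore stands as the one compound with a measured inhibitory concentration, and that number sits close to the limit of > 100000 nM in this assay, at which 2 of the 3 values shown sit.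

Compound 4, `O=C(/C(=N/O)Nc1ccc(F)c(Br)c1)C1CCN(C(=O)Nc2ccccc2)CC1`, has not been measured. It differs from compound 1 by phenyl in place of benzyl on an amide-type nitrogen; read one bond further out, the change is benzylamino to anilino, or benzylcarbamoyl to phenylcarbamoyl. For the measured compounds named here, no measured pair shows this change, so the size of the step is not known. Compound 2, which also carries a phenylcarbamoyl group, gives only the limit of > 100000 nM in this assay. Compound 1 itself, at 89800 nM, lies near (the limit of > 100000 nM in this assay, at which 2 of the 3 values shown sit). A step of no more than the scatter, or a weakening, is expected, with a real chance that only a limit is reported. The author estimates for compound 4 a value of 120000 nM in this assay, within 45000 nM to 320000 nM. This means an expected step of a 1.3-fold higher number from compound 1 to compound 4 (0.13 log units; within the scatter).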

Compound 4, half-maximal inhibitory concentration: 58000 nM
Compound 4: middle estimate off by 2.1-fold (0.32 log units), on the high side, within the range that was stated.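

In this assay, among these compounds, the exchange of benzyl for phenyl on the amide-type nitrogen gives the first direct reading of a change at this position: a 1.5-fold lower number from compound 1 to compound 4 (0.19 log units; within the scatter). This place therefore accepts the change without a step that can be told from repeat measurements, and the aromatic ring bound directly to the nitrogen still gives an outright number rather than a limit. The pair also shows that this exchange alone does not move the series clear of the top of the measurable range, as both numbers remain close to a limit of the assay: the limit of > 100000 nM in this assay, at which 2 of the 4 values shown sit.

The compounds shown leave open whether an aromatic ring is needed on this nitrogen at all, and how a methyl group, a phenethyl chain or a pyridyl ring would read there. They also leave open whether replacing the bromine with chlorine elsewhere in the shared core would give a clearer step, and whether the small difference between benzyl and phenyl would hold in a compound further from the limit.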